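Pyrazole for thiazole on the shared core

The source may report more compounds than this note shows. Statements on the series, on what has been measured and on what is new or still open speak of the compounds shown alone.

Four compounds share one core and differ only in the aromatic group attached to an aromatic carbon. In a functional assay on L1210 cells (Mus musculus) for inhibition (on this read-out higher numbers stand for weaker inhibition and lower numbers for stronger inhibition), compound 1 `OC[C@H]1OC(n2cnc3c(-c4ccccn4)ncnc32)[C@H](O)[C@@H]1O` gives 4300 nM, compound 2 `OC[C@H]1OC(n2cnc3c(-c4ccc(O)cc4)ncnc32)[C@H](O)[C@@H]1O` gives 5000 nM, and compound 3 `OC[C@H]1OC(n2cnc3c(-c4nccs4)ncnc32)[C@H](O)[C@@H]1O` gives 16000 nM. Among these three numbers compound 3 stands highest: the step of a 3.7-fold higher number from compound 1 to compound 3 (0.57 log units; beyond the scatter) and the step of a 3.2-fold higher number from compound 2 to compound 3 (0.51 log units; beyond the scatter) both lie beyond the scatter, while a 1.2-fold higher number from compound 1 to compound 2 (0.07 log units; within the scatter) stays within it. Compound 4 `OC[C@H]1OC(n2cnc3c(-c4cc[nH]n4)ncnc32)[C@H](O)[C@@H]1O` differs from compound 3 by 1H-pyrazol-3-yl in place of 1,3-thiazol-2-yl on an aromatic carbon. Among the compounds with values here, no measured step exchanges one five-membered ring for another; the two steps that end at compound 3 show only that the 1,3-thiazol-2-yl group gave a weaker result than either six-membered group. For compound 4 a modest fall in the number is expected, a 2.0-fold lower number from compound 3 to compound 4 (0.30 log units; within the scatter), though an outcome within the scatter of compound 3 cannot be excluded. Compound 4 is therefore estimated at 8000 nM, within a range from 3000 nM to 25000 nM.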

Compound 4, half-maximal inhibitory concentration: 19800 nM
Compound 4: the middle estimate sits 2.5-fold (0.39 log units) below what was measured, and the stated range covers the measured number.
By their numbers in this assay, from the lowest: compounds 1 and 2 (each within the scatter of the next); then compounds 3 and 4 (each within the scatter of the next).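

In this assay the exchange of one five-membered ring for another makes no readable difference (a 1.2-fold higher number from compound 3 to compound 4 (0.09 log units; within the scatter)), although the counts of hydrogen-bond donors and acceptors differ between 1,3-thiazol-2-yl and 1H-pyrazol-3-yl. Compound 4 also stands apart from both six-membered groups (a 4.0-fold higher number from compound 2 to compound 4 (0.60 log units; beyond the scatter); a 4.6-fold higher number from compound 1 to compound 4 (0.66 log units; beyond the scatter)), so the gap first seen with compound 3 appears again with a second five-membered ring, among these four compounds only. Nothing given here explains either that gap or the lack of a difference between the two five-membered groups.

From the compounds shown here alone, whether an amine or a longer chain on this aromatic carbon would change the number remains open. Also unresolved is whether any group at this position could take the number clearly below that of compound 1.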